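Methyl in Place of Bromo on an Aromatic Carbon

The source may report more compounds than this note shows. Statements on the series, on what has been measured and on what is new or still open speak of the compounds shown alone.

Of the compounds shown here, three sharing one core have been tested in an ADME assay on Vero cells (Chlorocebus sabaeus) for cytotoxicity, read by MTT assay, with a stated time of 72 h; on this read-out higher numbers stand for lower toxicity in this test and lower numbers for higher toxicity in this test. Compound 1, `CCc1nc2ccc(Cl)cn2c1C(=O)NCc1ccc2c(c1)CCN(Cc1ccc(C(F)(F)F)cn1)C2`, reads > 64 ug/mL, which is a limit of the assay and not a number. Compound 2, `CCc1nc2ccc(Cl)cn2c1C(=O)NCc1ccc2c(c1)CCN(Cc1ccc(F)cc1)C2`, reads > 64 ug/mL, which is likewise a limit. Within the data shown here, compound 3, `CCc1nc2ccc(Cl)cn2c1C(=O)NCc1ccc2c(c1)CCN(Cc1ccc(Br)cc1)C2`, gives 30 ug/mL, the only actual number among the three.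

Compound 4, `CCc1nc2ccc(Cl)cn2c1C(=O)NCc1ccc2c(c1)CCN(Cc1ccc(C)cc1)C2`, carries methyl in place of bromo on an aromatic carbon, para to a large group: methyl in place of bromo on an aromatic carbon.

The closest measured change is an at least 2.1-fold lower number from compound 2 to compound 3 (0.32 log units; beyond the scatter), which puts bromo in place of fluoro on an aromatic carbon. The step of an at least 2.1-fold lower number from compound 1 to compound 3 (0.32 log units; beyond the scatter) runs in the same direction, while a step that the two limits leave unreadable from compound 1 to compound 2 cannot be sized. Among the measured compounds shown here, both readable steps end at the one bromo compound, and both are bounded by a limit on one side, so they give a minimum size and not a true one. Losing the bromo may therefore recover part of that gap, but no methyl compound has been measured to confirm it. A small rise, possibly within the scatter, is expected in this assay, and the estimated change is a 1.5-fold higher number from compound 3 to compound 4 (0.18 log units; within the scatter). For compound 4 the expected value is 45 ug/mL, with an estimated range of 22 ug/mL to 90 ug/mL.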

Compound 4, half-maximal cytotoxic concentration: 51 ug/mL
Beside the measured number, compound 4's estimate is 1.1-fold (0.05 log units) below it; the measured number falls inside the stated range.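

In this assay, among these compounds, putting methyl in place of bromo on this aromatic carbon gives a 1.7-fold higher number from compound 3 to compound 4 (0.23 log units; within the scatter) and so the two groups cannot be told apart here, which means the bromo compound no longer stands alone as the one actual number at this position. The comparisons with the limit compounds stay loose: the change gives an at least 1.2-fold lower number from compound 2 to compound 4 (0.09 log units; that floor lies within the scatter) and the swap of the whole aryl group gives an at least 1.2-fold lower number from compound 1 to compound 4 (0.09 log units; that floor lies within the scatter) and, unlike the steps that end at compound 3, neither floor clears the scatter, so compound 4 cannot be set apart from compound 2 or from compound 1. Compounds 1 and 2 each read as a limit of the assay and not a number, so these two steps give only a minimum size: the limit of > 64 ug/mL in this assay, at which 2 of the 4 values shown sit.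

As far as these compounds go, how far compound 1 and compound 2 truly lie from compound 4 stays open, since only a floor is available for either gap. Also open, from the compounds shown here alone, is how a chloro, a methoxy or a carboxylic acid on the same aromatic carbon, para to a large group, would read in this assay on the shared core.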